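Sulfonylurea series: replacing the terminal group on the urea nitrogen

The source may hold more compounds than are shown below. What is called first, only, known or untested is meant among the compounds shown, and "the series" means these compounds.

Compound 1 `Cc1cc(C)n(-c2ccc(S(=O)(=O)NC(=O)NNC(=N)N)cc2)n1` gives 3% in a functional assay on the whole organism (blood, strain albino) with Mus musculus as the target, with stated times of 6 days and 4 h, at a dose of 0.4 mmol/kg by the oral route; a higher number here means more inhibition at the dose given (going by the name of the read-out), a lower number less inhibition; compound 2 `Cc1cc(C(=O)O)nn1-c1ccc(S(=O)(=O)NC(=O)NCc2ccccc2)cc1` gives 0% in the same test, a value that lies within the scatter of the first. Neither number shows an effect beyond what repeated measurements of this kind vary by. Compound 3 `CCCNC(=O)NS(=O)(=O)c1ccc(-n2nc(C)cc2C)cc1` differs from compound 1 only in the change (a group of 3 heavy atoms (3 carbon; no ring) in place of a group of 4 heavy atoms (1 carbon, 3 nitrogen; no ring), on an amide-type nitrogen). Among the compounds with values here, no measured step of this kind exists here, so the expectation for the step from compound 1 to compound 3 is one within the scatter, a number 3 percentage points higher from compound 1 to compound 3 (within the scatter), in no clear direction. Compound 3 is therefore expected to give 6% (range 0% to 20%).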

Compound 3, a percentage reported as inhibition, in the whole organism at one dose (the size of the read-out at that dose, not a potency): < 1%
Compound 3 ended at the assay's limit (the forecaster's own chance of this, stated with the estimate: 0%); at least 5 percentage points between middle value and limit.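

In this assay compound 3 gives < 1%, which is a limit of the assay and not a number. Propyl in place of the nitrogen-containing group on the amide-type nitrogen gives a number at least 2 percentage points lower from compound 1 to compound 3 (that floor lies within the scatter), so this change brings out no inhibition at the dose given. The size of the step can be read no further than this: the limit of < 1% in this assay, at which 1 of the 3 values shown sits.

On these data alone, whether a longer chain such as hexyl, or a cyclohexyl ring, on this nitrogen gives inhibition beyond the scatter stays open. The same holds for a propyl chain ending in an amine or a carboxylic acid.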